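Swapping a dihydroxyethyl chain for a hydroxypropyl chain

A few compounds are considered here, and "the series" means these few. Any claim that something is new, unique, unknown or untested is made for them only; others in the source may bear on it.

Measured compounds:
compound 1 `OCC(O)Cn1nc2c(Br)c(Br)c(Br)c(Br)c2n1` gives 116%
compound 2 `OC(CCn1nc2c(Br)c(Br)c(Br)c(Br)c2n1)c1ccccc1` gives 113%
compound 3 `COc1cccc(C(O)CCn2nc3c(Br)c(Br)c(Br)c(Br)c3n2)c1` gives 97%

All three share one core and were tested in a functional assay on MCF7 cells (Homo sapiens) for antiproliferative activity, read by MTT assay, with a stated time of 48 h, tested at 12.5 uM; on this read-out lower numbers stand for a stronger effect and higher numbers for a weaker effect at the one concentration tested. Compound 1 sits at the high end of the three numbers; against compound 2 its gap is within the scatter, and against compound 3 it is beyond it. Among the measured compounds shown here, the only step between compounds differing in one place is a number 16 percentage points lower from compound 2 to compound 3 (beyond the scatter), a change on the aromatic ring, not on the chain. Compound 4 `C[C@H](O)CCn1nc2c(Br)c(Br)c(Br)c(Br)c2n1` differs from compound 1 by 2-hydroxypropyl in place of 1,2-dihydroxyethyl on a saturated chain carbon bound to an aromatic nitrogen. For the measured compounds named here, no measured step touches a chain change of this kind, and compound 1 and compound 2, which carry different chains, lie within the scatter of each other, so the expected step of a number 4 percentage points lower from compound 1 to compound 4 (within the scatter) is none beyond the scatter. Compound 4 is therefore estimated at 112%, within 95% to 130%.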

Compound 4, a percentage reported as activity, at one concentration (the size of the read-out at that concentration, not a potency): 100%
The estimate for compound 4 lay 12 percentage points above the measured number; the measured number falls inside the stated range.
By their numbers in this assay, from the lowest: compounds 3 and 4 (each within the scatter of the next); then compounds 2 and 1 (each within the scatter of the next).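

The change from 1,2-dihydroxyethyl to 2-hydroxypropyl on a saturated chain carbon bound to an aromatic nitrogen gives a number 16 percentage points lower from compound 1 to compound 4 (beyond the scatter) in this assay and is the only step shown that touches the chain. The read-out at this concentration therefore responds to the chain as well as to a substituent on the aromatic ring. Nothing here explains why this change shifts the number.

Still open, as far as these compounds go, is whether an amine, a carboxylic acid or a longer chain at this position would shift the number further. Also open, from the compounds shown here alone, is whether the mirror-image form of compound 4 would read the same.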